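Demethylation at the ring oxygen: compound 3 to compound 4

The compounds below may be only part of what the source reports. "The series", "measured", "known", "first", "only" and "open" are said of these compounds alone.

Measured compounds:
compound 1 `CCOC(=O)c1cnc(-c2ccccc2)s1` — > 100000 nM
compound 2 `CCOC(=O)c1sc(-c2ccc(F)cc2)nc1O` — 80 nM
compound 3 `CCOC(=O)c1sc(-c2ccccc2)nc1OC` — > 100000 nM

In an assay on HEK293 cells for inhibition of transient receptor potential cation channel subfamily M member 8 (Homo sapiens), read by FLIPR, with stated times of 5 min and 3 min (on this read-out higher numbers stand for weaker inhibition and lower numbers for stronger inhibition), compound 1 gives > 100000 nM, which is a limit of the assay and not a number. Compound 3 likewise gives only > 100000 nM in this assay, again a limit. Compound 2, which carries a hydroxy group on the shared core together with a fluorine on the phenyl ring, gives 80 nM. Compound 3 therefore stands at the limit, where two of the three values sit (the limit of > 100000 nM in this assay, at which 2 of the 3 values shown sit); the step that the two limits leave unreadable from compound 1 to compound 3 stays unreadable for that reason, and no other measured pair speaks to compound 3.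

Compound 4 `CCOC(=O)c1sc(-c2ccccc2)nc1O` differs from compound 3 by hydrogen in place of methyl on an oxygen on an aromatic ring. Among the measured compounds shown here, no measured step covers this exact change. What bears on it is compound 2: the hydroxy analogue with fluorine is a strong inhibitor, whereas the methoxy compound 3 sits at the limit. A large step towards stronger inhibition is expected for compound 4, an at least 500-fold lower number from compound 3 to compound 4 (2.69 log units; beyond the scatter), though its size against a limit remains uncertain. The estimate for compound 4 is 200 nM, in the range 40 nM to 2000 nM.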

Compound 4, half-maximal inhibitory concentration: 32 nM
The estimate for compound 4 lay 6.3-fold (0.80 log units) above the measured number; the whole stated range lies above it.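

In this assay, methoxy to hydroxy gives an at least 3100-fold lower number from compound 3 to compound 4 (3.49 log units; beyond the scatter), and hydroxy in place of hydrogen on the aromatic carbon gives an at least 3100-fold lower number from compound 1 to compound 4 (3.49 log units; beyond the scatter), so at this position only hydroxy, of the three groups shown, gives a measured number. Both steps are minimum sizes, since compound 1 and compound 3 each stand at a limit and not a number: the limit of > 100000 nM in this assay, at which 2 of the 4 values shown sit. Hydrogen in place of fluoro on an aromatic carbon gives a 2.5-fold lower number from compound 2 to compound 4 (0.40 log units; beyond the scatter), a modest step, so the fluoro is not required for inhibition in this pair.

The step between the two limits, from compound 1 to compound 3, cannot be read, so methoxy and hydrogen stay unranked. Open too, going by these compounds, is whether an amine or a carboxylic acid at the hydroxy position would keep the inhibition.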